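From trifluoromethyl to methyl in a small series

The source may report more compounds than this note shows. Statements on the series, on what has been measured and on what is new or still open speak of the compounds shown alone.

Compound 1 `FC(F)(F)c1ccc(/C=C/[C@@H]2CCCCN2)cc1`: 0.99 ug/mL
Compound 2 `C(=C/[C@@H]1CCCCN1)\c1ccccc1`: 10.5 ug/mL
Compound 3 `Cc1ccc(/C=C/[C@@H]2CCCCN2)cc1`: not yet measured

Among the compounds with values here, in a functional assay on OVCAR-3 cells (Homo sapiens) for inhibition, read by MTT assay, with a stated time of 24 h (a higher number here means a weaker inhibitor, a lower number a stronger inhibitor), compound 1 gives 0.99 ug/mL, the lower of the two numbers so far, which makes it the stronger inhibitor of the measured pair. Compound 3 keeps the core of compound 1 and changes one group, with methyl in place of trifluoromethyl on an aromatic carbon.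

Within the data shown here, one measured step bears on this change. Hydrogen in place of trifluoromethyl on an aromatic carbon gives compound 2 at 10.5 ug/mL, a large step beyond the scatter: an 11-fold higher number from compound 1 to compound 2 (1.03 log units; beyond the scatter). Among the measured compounds shown here, that step removes the same group, but no measured compound carries methyl, and the direction rests on this single pair. In this assay a weaker result is therefore expected, with a step smaller than that large one. The estimated step is a 4.0-fold higher number from compound 1 to compound 3 (0.61 log units; beyond the scatter). The expected value for compound 3 is 4 ug/mL, with an estimated range from 1.3 ug/mL to 11 ug/mL.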

Compound 3, half-maximal inhibitory concentration: 8.48 ug/mL
Compound 3: middle estimate off by 2.1-fold (0.33 log units), on the low side; the range from low to high includes it.
By their numbers in this assay, from the lowest: compound 1; then compounds 3 and 2 (each within the scatter of the next).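

In this assay the change to methyl gives an 8.6-fold higher number from compound 1 to compound 3 (0.93 log units; beyond the scatter) and so shows that keeping a carbon on this aromatic carbon does not by itself preserve the low number of compound 1. Set against hydrogen, the same methyl gives a 1.2-fold lower number from compound 2 to compound 3 (0.09 log units; within the scatter) and thus no readable change, so among these three compounds only trifluoromethyl stands apart, and none of them goes against that reading. Nothing available here says what lies behind this difference.

On these data alone, whether the low number of compound 1 depends on having all three fluorine atoms stays open, since only trifluoromethyl carries fluorine here and a single fluorine, a chlorine or a nitrile on the same aromatic carbon could fall on either side of the gap. As far as these compounds go, it is also open how a methoxy group, an amine or a carboxylic acid would behave in this place, and whether trifluoromethyl would stand apart in the same way on another carbon of the ring.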